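A few compounds are considered here, and "the series" means these few. Any claim that something is new, unique, unknown or untested is made for them only; others in the source may bear on it.

Measured so far in an ADME assay on Vero cells (Chlorocebus sabaeus) for cytotoxicity, read by neutral red uptake, with a stated time of 48 h; a higher number here means a weaker inhibitor, a lower number a stronger inhibitor:
Compound 1 `CCN(CC)c1nc(Cl)nc2c1ncn2CCCNc1ccnc2cc(Cl)ccc12` gives > 10700 nM
Compound 2 `CCN1CCN(c2nc(Cl)nc3c2ncn3CCCNc2ccnc3cc(Cl)ccc23)CC1` gives > 9830 nM

Compound 1 has only a limit of the assay and no number. Compound 2 stands at > 9830 nM as a limit too. Compound 3 `Clc1ccc2c(NCCCn3cnc4c(N5CCN(c6ccccc6)CC5)nc(Cl)nc43)ccnc2c1` differs from compound 2 as follows: phenyl in place of ethyl on an amine nitrogen in a ring and so carries phenyl in place of ethyl on an amine nitrogen in a ring. Going by the values given here, the one measured step that bears on this is a step that the two limits leave unreadable from compound 1 to compound 2 and it gives no size to build on. The expected change is therefore an at least 1.1-fold lower number from compound 2 to compound 3 (0.04 log units; that floor lies within the scatter) and no step beyond the scatter is expected. For compound 3 the estimated value is 8900 nM with an expected range from 3000 nM to 20000 nM in this assay and a further limit is likely.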

Compound 3, half-maximal inhibitory concentration: > 8900 nM
Compound 3 gave a limit, no number (the forecaster's own chance of this, stated with the estimate: 75%); the middle value lies on the limit itself.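

Going by these compounds alone, compound 1, compound 2 and compound 3 each give only a limit of the assay, and no step between them can be read. Still open, going by these compounds, is whether diethylamino, 4-ethylpiperazin-1-yl and 4-phenylpiperazin-1-yl differ at all in their effect on these cells.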